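Thiazole to ethylthiophene on the benzylic amine: expected effect

The source may hold more compounds than are shown below. What is called first, only, known or untested is meant among the compounds shown, and "the series" means these compounds.

Measured compounds in an ADME assay on Huh-7 cells (Homo sapiens) for cytotoxicity, read by MTT assay, with a stated time of 96 h; on this read-out higher numbers stand for lower toxicity in this test and lower numbers for higher toxicity in this test:
compound 1, `COc1cc(NCc2scnc2C)ccc1-c1cnco1`, gives 58500 nM
compound 2, `COc1cc(NCc2ccc(Cl)s2)ccc1-c1cnco1`, gives 43200 nM
compound 3, `COc1cc(NCc2cncs2)ccc1-c1cnco1`, gives 68900 nM

All three share one core and differ only in the ring carried on the saturated chain carbon bound to the ring nitrogen. Of the three numbers, that of compound 3 is the largest, yet a 1.2-fold higher number from compound 1 to compound 3 (0.07 log units; within the scatter) and a 1.6-fold higher number from compound 2 to compound 3 (0.20 log units; within the scatter) both lie within the scatter, so the three compounds are not told apart in this assay .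

Compound 4, `CCc1ccc(CNc2ccc(-c3cnco3)c(OC)c2)s1`, is not yet measured. It differs from compound 3 in one place: 5-ethylthiophen-2-yl in place of 1,3-thiazol-5-yl on a saturated chain carbon bound to a nitrogen on an aromatic ring. Among the compounds with values here, the closest precedent is the opposite swap, in which a thiophene was replaced by a thiazole, giving a 1.6-fold higher number from compound 2 to compound 3 (0.20 log units; within the scatter); the step of a 1.4-fold lower number from compound 1 to compound 2 (0.13 log units; within the scatter) also exchanged a thiazole for a thiophene. Both stayed within the scatter, so no step beyond the scatter is expected here, if anything a slightly lower number. Compound 4 is therefore expected to give about 45000 nM, within a range from 22000 nM to 90000 nM. This corresponds to an expected step of a 1.5-fold lower number from compound 3 to compound 4 (0.19 log units; within the scatter).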

Compound 4, half-maximal cytotoxic concentration: 39100 nM
The estimate for compound 4 lay 1.2-fold (0.06 log units) above the measured number; low and high end bracket the measured number.
By their numbers in this assay, from the lowest: compounds 4, 2, 1 and 3 (each within the scatter of the next).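

Compound 4 brings an ethyl chain onto the ring at this position, and replacing the 1,3-thiazol-5-yl with 5-ethylthiophen-2-yl in this assay gives a 1.8-fold lower number from compound 3 to compound 4 (0.25 log units; within the scatter). Ethyl in place of chloro on an aromatic carbon, a change the earlier compounds did not include, gives a 1.1-fold lower number from compound 2 to compound 4 (0.04 log units; within the scatter), while the swap from 4-methyl-1,3-thiazol-5-yl gives a 1.5-fold lower number from compound 1 to compound 4 (0.17 log units; within the scatter). The four compounds therefore remain not told apart in this test, even with ethyl as the new group, and nothing shown here explains their numbers.

Still open, as far as these compounds go, is whether an amine, a carboxylic acid or a chain longer than ethyl on this ring would produce a step beyond the scatter. The compounds shown also cannot say whether the same holds in other cells or at another exposure time.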